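Swapping 1H-pyrrol-3-yl for 5-formylfuran-2-yl on the shared core

The source may report more compounds than this note shows. Statements on the series, on what has been measured and on what is new or still open speak of the compounds shown alone.

Measured so far in a functional assay on MV4-11 cells (Homo sapiens) for inhibition, read by resazurin assay, with a stated time of 72 h (a lower number here means a stronger inhibitor of growth, a higher number a weaker inhibitor of growth), are two compounds:
compound 1 `O=C1NCCC12CCN(c1c(Cl)cncc1-c1cccs1)CC2` gives 480 nM here
compound 2 `O=C1NCCC12CCN(c1c(Cl)cncc1-c1cc[nH]c1)CC2` gives 1050 nM here

Compound 2 holds the higher of the two numbers. Among the compounds with values here, the only measured step (a 2.2-fold higher number from compound 1 to compound 2 (0.34 log units; beyond the scatter)) replaced thiophen-2-yl with 1H-pyrrol-3-yl on the same aromatic carbon. Compound 3 `O=Cc1ccc(-c2cncc(Cl)c2N2CCC3(CCNC3=O)CC2)o1` carries 5-formylfuran-2-yl in place of 1H-pyrrol-3-yl on that carbon (5-formylfuran-2-yl in place of 1H-pyrrol-3-yl on an aromatic carbon). Within the data shown here, with only that modest step to go on, a change of no greater size is expected in this assay and, tentatively, toward a lower number. The estimated step (a 1.5-fold lower number from compound 2 to compound 3 (0.18 log units; within the scatter)) stays small. For compound 3 the expected value is 700 nM within an estimated range from 250 nM to 2000 nM in this assay.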

Compound 3, concentration for 50% growth inhibition: 5190 nM
Beside the measured number, compound 3's estimate is 7.4-fold (0.87 log units) below it; the measured number lies above the stated range.
By their numbers in this assay, from the lowest: compound 1; then compound 2; then compound 3.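

In this assay, the change to 5-formylfuran-2-yl gave a 4.9-fold higher number from compound 2 to compound 3 (0.69 log units; beyond the scatter) and an 11-fold higher number from compound 1 to compound 3 (1.03 log units; beyond the scatter). Within the data shown here, this aromatic carbon therefore responds more strongly to the choice of group than the single earlier step showed, and the formyl-bearing furan stands with the highest number of the three. Compared with 1H-pyrrol-3-yl, the entering group has no hydrogen-bond donor, has two acceptors and carries a double bond outside the ring, and no measured evidence explains the result.

From the compounds shown here alone, it remains open whether the formyl group or the furan ring accounts for the rise. Unsubstituted furan-2-yl, or a hydroxymethyl or carboxylic acid in place of the formyl, would bear on that question.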